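Swapping Trifluoromethyl for Dimethylamino on the Benzamide Ring

The source may report more compounds than this note shows. Statements on the series, on what has been measured and on what is new or still open speak of the compounds shown alone.

Measured so far:
compound 1 `O=C(c1ccc(Cl)cc1)N1CCC(NS(=O)(=O)c2cc(S(=O)(=O)c3ccccc3)ccc2C(F)(F)F)CC1` gives 1800 nM
compound 2 `O=C(c1ccc(C(F)(F)F)cc1)N1CCC(NS(=O)(=O)c2cc(S(=O)(=O)c3ccccc3)ccc2C(F)(F)F)CC1` gives 970 nM

Both compounds were tested in an assay on U2OS cells for inhibition of secreted frizzled-related protein 1 (Homo sapiens), read by a luciferase reporter, with a stated time of 18 h; on this read-out higher numbers stand for an effect only at larger amounts of compound and lower numbers for an effect already at smaller amounts. Within the data shown here, compound 2 stands next to compound 1 with no gap worth reading: the only measured step, a 1.9-fold lower number from compound 1 to compound 2 (0.27 log units; within the scatter), stays within the scatter, so the two numbers count as alike.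

Compound 3 `CN(C)c1ccc(C(=O)N2CCC(NS(=O)(=O)c3cc(S(=O)(=O)c4ccccc4)ccc3C(F)(F)F)CC2)cc1` differs from compound 2 in one place: dimethylamino in place of trifluoromethyl on an aromatic carbon. Among the measured compounds shown here, no measured step involves a dimethylamino group, and the one step that is known, a 1.9-fold lower number from compound 1 to compound 2 (0.27 log units; within the scatter), exchanges two groups at that same place without a change beyond the scatter. It therefore offers no direction for the new exchange. The expectation for compound 3 in this assay is anchored on compound 2 with a wide range and no clear direction; the expected step is a 1.5-fold higher number from compound 2 to compound 3 (0.19 log units; within the scatter). Compound 3 is expected to give 1500 nM, between 400 nM and 6000 nM.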

Compound 3, half-maximal effective concentration: 190 nM
Beside the measured number, compound 3's estimate is 7.9-fold (0.90 log units) above it, and the stated range ends above it.
By their numbers in this assay, from the lowest: compound 3; then compounds 2 and 1 (each within the scatter of the next).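

Swapping groups at this place on the aromatic ring, para to a large group, can move the number beyond the scatter, which the exchange of chloro and trifluoromethyl did not show: dimethylamino in place of trifluoromethyl gives a 5.1-fold lower number from compound 2 to compound 3 (0.71 log units; beyond the scatter), and dimethylamino in place of chloro gives a 9.5-fold lower number from compound 1 to compound 3 (0.98 log units; beyond the scatter). In this assay, dimethylamino therefore stands apart from both earlier groups, with an effect already at smaller amounts of compound. Dimethylamino carries one hydrogen-bond acceptor and trifluoromethyl none, but no measurement here connects that count or any other feature of the group to the lower number.

The three compounds shown leave open whether the nitrogen itself matters, which a plain amino group or a methoxy group at this place could help to test. They also leave open whether a cyclic amine such as pyrrolidine would give a similar number.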